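The compounds below may be only part of what the source reports. "The series", "measured", "known", "first", "only" and "open" are said of these compounds alone.

Compound 1 `CC(C)COC(=O)N1CCN(C(=O)c2nc(Nc3cc(C4CC4)[nH]n3)c3cc(Cl)ccc3n2)C[C@H]1C` and compound 2 `CC(OC(=O)C(C)C)OC(=O)N1CCN(C(=O)c2nc(Nc3cc(C4CC4)[nH]n3)c3cc(Cl)ccc3n2)C[C@H]1C` share one core and differ only in the group on an oxygen next to a carbonyl group. In an assay for inhibition of serine/threonine-protein kinase PAK 4 (Homo sapiens), read by FRET and Z'-LYTE, with a stated time of 60 min, tested at 50 uM, in the presence of a further agent that is not named here (a higher number here means a stronger effect of the compound at the concentration tested, a lower number a weaker effect), compound 1 gives 46.9%, while compound 2 gives 71.7%. For the measured compounds named here, that difference, a number 24.8 percentage points higher from compound 1 to compound 2 (beyond the scatter), is the only measured step so far, and it places compound 2 at the top of the two numbers, with compound 1 the nearest neighbour.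

Compound 3 `C[C@@H]1CN(C(=O)c2nc(Nc3cc(C4CC4)[nH]n3)c3cc(Cl)ccc3n2)CCN1C(=O)OCC(Cl)(Cl)Cl` is the next case, again altered only at that same oxygen: 2,2,2-trichloroethyl in place of 1-((isopropylcarbonyl)oxy)ethyl on an oxygen next to a carbonyl group. Going by the values given here, no measured pair shows this exact exchange, so the one step that bears on it is the earlier change at the same position, which moved the read-out by a modest amount. Among the compounds with values here, because that step from compound 1 to compound 2 was a number 24.8 percentage points higher from compound 1 to compound 2 (beyond the scatter), the expectation is a step of comparable size for compound 3, more likely downward than upward, since compound 2 already holds the higher of the two known numbers. Compound 3 is therefore estimated at 55% in this assay, within a range from 35% to 75%, which corresponds to an expected a number 16.7 percentage points lower from compound 2 to compound 3 (beyond the scatter).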

Compound 3, a percentage reported as inhibition, at one concentration (the size of the read-out at that concentration, not a potency) in the serine/threonine-protein kinase PAK 4 assay: 82.8%
Compound 3: middle estimate off by 27.8 percentage points, on the low side, outside the stated range (above it).
By their numbers in the serine/threonine-protein kinase PAK 4 assay, from the lowest: compound 1; then compound 2; then compound 3.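

In the serine/threonine-protein kinase PAK 4 assay, the oxygen next to a carbonyl group does not need the 1-((isopropylcarbonyl)oxy)ethyl group to give a high read-out: compound 2 gives 71.7%, and compound 3, with 2,2,2-trichloroethyl, fewer heavy atoms and no hydrogen-bond acceptors, gives 82.8%, which is a number 11.1 percentage points higher from compound 2 to compound 3 (beyond the scatter). The closest comparison is trichloromethyl in place of isopropyl on a saturated chain carbon bound to that oxygen, where the serine/threonine-protein kinase PAK 4 assay shows a number 35.9 percentage points higher from compound 1 to compound 3 (beyond the scatter), so a change at the end of the chain alone can move this read-out a long way. In a physicochemical assay, read by HPLC, in phosphate buffer, with a stated time of 2 h, at pH 7.4 (on this read-out higher numbers stand for a more stable compound and lower numbers for a less stable compound), compound 2 gives 96.6% and compound 3 gives 98.7%, and the exchange gives a number 2.1 percentage points higher from compound 2 to compound 3 (within the scatter), so the gain in the kinase read-out comes with no measurable difference on this stability read-out.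

From the compounds shown here alone, whether the chlorine atoms themselves matter stays open, and 2,2,2-trifluoroethyl or a plain ethyl group on the same oxygen would help to separate their role from that of the chain. Nothing shown here explains why either step occurs.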